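The compounds below may be only part of what the source reports. "The series", "measured", "known", "first", "only" and "open" are said of these compounds alone.

In an ADME assay on a cell-free system (plasma, Homo sapiens) for metabolic stability, with a stated time of 2 h (a lower number here means that less of the compound is left, a higher number that more of the compound is left), compound 2 (`Nc1ccc(-c2ccc3ncc(-c4nnco4)c(NCCCn4ccnc4)c3c2)cc1`) gives 91.3% and compound 1 (`COc1ccc(-c2ccc3ncc(-c4nnco4)c(NCCCn4ccnc4)c3c2)cc1`) gives 93.3%, so the two stand within the usual scatter of each other. Compound 3 (`Cc1ccc(-c2ccc3ncc(-c4nnco4)c(NCCCn4ccnc4)c3c2)cc1`) has methyl in place of amino on an aromatic carbon, para to a large group: methyl in place of amino on an aromatic carbon. Among the compounds with values here, the one measured step at this place, amino in place of methoxy, is a number 2 percentage points lower from compound 1 to compound 2 (within the scatter), and it stays within the scatter. No step beyond the scatter is therefore expected in this assay, and the estimated step is a number 0.7 percentage points higher from compound 2 to compound 3 (within the scatter). For compound 3 the expected value is 92%, with an estimated range of 84% to 99%.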

Compound 3, percent of the compound remaining in the Homo sapiens assay: 90.8%
Beside the measured number, compound 3's estimate is 1.2 percentage points above it; measured number inside the range.
By their numbers in the Homo sapiens assay, from the lowest: compounds 3, 2 and 1 (each within the scatter of the next).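

Methyl on the aromatic carbon para to a large group stands within the scatter of both amino and methoxy: in the Homo sapiens assay the step is a number 0.5 percentage points lower from compound 2 to compound 3 (within the scatter), and in the Homo sapiens assay the step is a number 2.5 percentage points lower from compound 1 to compound 3 (within the scatter). This place is not silent, however: in a physicochemical assay for solubility (on this read-out lower numbers stand for lower solubility and higher numbers for higher solubility), compound 2 gives 30.2 ug/mL and compound 3 gives 0.3 ug/mL, so methyl in place of amino separates the two compounds far beyond the scatter, which the earlier compounds did not show: the measured solubility of compound 2, 30.2 ug/mL, and of compound 3, 0.3 ug/mL, a 100-fold lower number (2.00 log units; beyond the scatter)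

Open, going by these compounds, is how a hydroxyl or a carboxylic acid at this place would stand in the physicochemical assay and in the Homo sapiens assay.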